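This account rests on a few compounds, and the source may have more. Where it says the series, first, only, none or still open, it means among the compounds named here.

Measured in an ADME assay on MDBK cells (Bos taurus) for cytotoxicity, read by MTT assay, with a stated time of 72 h; a lower number here means that less compound is tolerated, a higher number that more compound is tolerated:
- compound 1 `FC(F)(F)c1ccc(-c2nn(-c3ccccc3)cc2CNc2ccc(Cl)cc2)cc1`: 44000 nM
- compound 2 `Cc1ccc(NCc2cn(-c3ccccc3)nc2-c2ccc(C(F)(F)F)cc2)cc1`: > 100000 nM

The reading for compound 2 is a limit and not a number. As far as these compounds go, compound 2 therefore sits at the limit of > 100000 nM in this assay, at which 1 of the 2 values shown sits, and its true position is unknown.

The next structure is compound 3 `Cc1ccc(NCc2cn(-c3ccccc3)nc2-c2ccc(Br)cc2)cc1`, which carries bromo in place of trifluoromethyl on an aromatic carbon, para to a large group (bromo in place of trifluoromethyl on an aromatic carbon).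

For the measured compounds named here, only one measured step is available: an at least 2.2-fold higher number from compound 1 to compound 2 (0.35 log units; beyond the scatter), with methyl in place of chloro on an aromatic carbon. That change falls on a different aromatic ring from the one altered now, so it bears only indirectly, as a guide to how far one small substituent swap can move this assay. Compound 1, at 44000 nM, shows that this series can give a number inside the measurable range. A modest move to a lower number is therefore expected, though a second reading at the limit would be no surprise.

The estimated step is an at least 1.3-fold lower number from compound 2 to compound 3 (0.12 log units; that floor lies within the scatter).

For compound 3 the expected value is 75000 nM, with an estimated range of 30000 nM to 100000 nM.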

Compound 3, half-maximal cytotoxic concentration: > 100000 nM
Compound 3: no number, only a limit; the forecaster's own chance of this, stated with the estimate: 45%; middle value at least 1.3-fold (0.12 log units) from the limit.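

In this assay compound 3 reads > 100000 nM, which is a limit and not a number. Compound 2 also sits at a limit, so no step between compound 2 and compound 3 can be read: the limit of > 100000 nM in this assay, at which 2 of the 3 values shown sit.

The compounds shown leave open whether bromo in place of trifluoromethyl changes the tolerated concentration at all.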